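The source may report more compounds than this note shows. Statements on the series, on what has been measured and on what is new or still open speak of the compounds shown alone.

Measured compounds in an ADME assay on L6 cells (Rattus norvegicus) for cytotoxicity, read by resazurin assay, with a stated time of 72 h; a higher number here means a weaker inhibitor, a lower number a stronger inhibitor:
- compound 1 `O=C1[C@H]2N=NN(Cc3nc(-c4ccc(Cl)cc4)no3)[C@H]2C(=O)N1c1ccccc1` gives 49.5 ug/mL
- compound 2 `O=C1[C@H]2N=NN(Cc3nc(-c4ccc(C(F)(F)F)cc4)no3)[C@H]2C(=O)N1c1ccccc1` gives 44.4 ug/mL
- compound 3 `O=C1[C@H]2N=NN(Cc3nc(-c4ccc(F)cc4)no3)[C@H]2C(=O)N1c1ccccc1` gives > 100 ug/mL, which is a limit of the assay rather than a number

Among the two numbers, compound 2 stands lowest, with compound 1 nearest a 1.1-fold lower number from compound 1 to compound 2 (0.05 log units; within the scatter). Compound 3 sits at the limit of > 100 ug/mL in this assay, at which 1 of the 3 values shown sits.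

Compound 4 `CN(C)c1ccc(-c2noc(CN3N=N[C@@H]4C(=O)N(c5ccccc5)C(=O)[C@@H]43)n2)cc1` is not yet measured. It differs from compound 2 in one place: dimethylamino in place of trifluoromethyl on an aromatic carbon.

Going by the values given here, two measured steps touch the same place. The step of a 1.1-fold lower number from compound 1 to compound 2 (0.05 log units; within the scatter) is within the scatter; the step of an at least 2.2-fold higher number from compound 2 to compound 3 (0.35 log units; beyond the scatter) is at least modest and ends at the limit. Among the compounds with values here, neither brings in dimethylamino, so no measured step speaks directly to this change. Exchanges at this position have so far given one flat step and one upward step, and nothing downward.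

Compound 4 is therefore expected to give 60 ug/mL, with a range from 30 ug/mL to 120 ug/mL, and a fair chance that only a limit is reported. The expected step from compound 2 is a 1.4-fold higher number from compound 2 to compound 4 (0.13 log units; within the scatter), which may not exceed the scatter.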

Compound 4, half-maximal inhibitory concentration: > 100 ug/mL
Compound 4: a limit, no number; the forecaster's own chance of this, stated with the estimate: 35%; at least 1.6-fold (0.22 log units) between middle value and limit.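

In this assay, the change from 4-(trifluoromethyl)phenyl to 4-(dimethylamino)phenyl gives an at least 2.2-fold higher number from compound 2 to compound 4 (0.35 log units; beyond the scatter), and dimethylamino in place of chloro gives an at least 2.0-fold higher number from compound 1 to compound 4 (0.30 log units; that floor lies within the scatter). A higher number at this position therefore does not depend on fluoro: a group with nitrogen and no halogen moves the same way, and exchanges here still show nothing downward. Compound 4 stands at a limit rather than a number, so the step between compound 3 and compound 4 cannot be read, and both sit at the same limit: the limit of > 100 ug/mL in this assay, at which 2 of the 4 values shown sit.

Going by these compounds, how far compound 3 and compound 4 lie beyond that limit stays open. Also open, on these data alone, is whether a primary amine, a methoxy group or a carboxylic acid at this position would return a number, and whether any group would fall below compound 1 and compound 2.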